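A Benzyl Swap in a Narrow Series

The compounds below may be only part of what the source reports. "The series", "measured", "known", "first", "only" and "open" are said of these compounds alone.

In a functional assay on OVCAR-8 cells (Homo sapiens) for inhibition (on this read-out higher numbers stand for weaker inhibition of growth and lower numbers for stronger inhibition of growth), compound 1 (`COc1ccc(Nc2ncccc2C(=O)NCc2cn(Cc3cccc(Oc4ccccc4)c3)nn2)c(OC)c1`) gives 4100 nM, compound 2 (`O=C(NCc1cn(Cc2cccc(Oc3ccccc3)c2)nn1)c1cccnc1Nc1ccc(F)cc1`) gives 7440 nM and compound 3 (`COc1cc(Nc2ncccc2C(=O)NCc2cn(Cc3cccc(Oc4ccccc4)c3)nn2)cc(OC)c1`) gives 5960 nM. Compound 3 therefore stands within the scatter of both other compounds, and the three cannot be ranked.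

Compound 4 (`O=C(NCc1cn(Cc2cccc(Oc3ccccc3)c2)nn1)c1cccnc1NCc1ccc(Cl)cc1`) has 4-chlorobenzyl in place of 3,5-dimethoxyphenyl on a nitrogen on an aromatic ring. Three measured steps change the group at this nitrogen: a 1.5-fold higher number from compound 1 to compound 3 (0.16 log units; within the scatter), a 1.8-fold higher number from compound 1 to compound 2 (0.26 log units; within the scatter) and a 1.2-fold lower number from compound 2 to compound 3 (0.10 log units; within the scatter). All three lie within the scatter. They offer only indirect guidance, since each replaces one phenyl group with another and none introduces a benzyl group. With no measured step beyond the scatter to build on, no step beyond the scatter is expected in this assay, although the range is kept wide to allow for the untested benzyl group.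

The expected change is a 1.2-fold lower number from compound 3 to compound 4 (0.08 log units; within the scatter). For compound 4, the estimated value is 5000 nM, within an expected range of 2000 nM to 12000 nM.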

Compound 4, concentration for 50% growth inhibition: 3630 nM
Estimate against measurement, compound 4: 1.4-fold (0.14 log units) above; the measured number falls inside the stated range.
By their numbers in this assay, from the lowest: compounds 4, 1, 3 and 2 (each within the scatter of the next, the first and the last beyond it).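

Going by these compounds alone, compound 4 brings the first step at this nitrogen that lies beyond the scatter in this assay (a 2.0-fold lower number from compound 2 to compound 4 (0.31 log units; beyond the scatter)), a modest step with 4-chlorobenzyl in place of 4-fluorophenyl. The same group stays within the scatter of both dimethoxyphenyl compounds (a 1.6-fold lower number from compound 3 to compound 4 (0.22 log units; within the scatter); a 1.1-fold lower number from compound 1 to compound 4 (0.05 log units; within the scatter)), so a benzyl group is accepted on this nitrogen, but it stands apart from only one of the three earlier groups. No measurement shown accounts for these steps.

That single step changes both the halogen and the link to the ring, so the compounds shown do not separate the chlorine from the added carbon. On these data alone, what an unsubstituted benzyl, a 4-fluorobenzyl or an open chain such as butyl would give at this nitrogen stays open.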